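A Methyl Added to Compound 3

The source may report more compounds than this note shows. Statements on the series, on what has been measured and on what is new or still open speak of the compounds shown alone.

compound 1 `COc1cc(Nc2nc3ccccc3nc2S(=O)(=O)c2ccccc2)cc(OC)c1` gives 50 nM
compound 2 `Nc1ccc(Nc2nc3ccccc3nc2S(=O)(=O)c2ccccc2)cc1` gives 8720 nM
compound 3 `Nc1cccc(Nc2nc3ccccc3nc2S(=O)(=O)c2ccccc2)c1` gives 1750 nM

In a functional assay on HL-60 cells (Homo sapiens) for cytotoxicity, read by MTT assay, with a stated time of 72 h (on this read-out lower numbers stand for stronger inhibition and higher numbers for weaker inhibition), compound 3 gives 1750 nM, the middle of the three numbers. Compound 4 `Cc1ccc(S(=O)(=O)c2nc3ccccc3nc2Nc2cccc(N)c2)cc1` changes it by methyl in place of hydrogen on an aromatic carbon, placing methyl in place of hydrogen on an aromatic carbon, so phenyl becomes 4-methylphenyl. The measured steps are a 170-fold higher number from compound 1 to compound 2 (2.24 log units; beyond the scatter), a 35-fold higher number from compound 1 to compound 3 (1.54 log units; beyond the scatter) and a 5.0-fold lower number from compound 2 to compound 3 (0.70 log units; beyond the scatter). All three change the group on the nitrogen, and none changes this phenyl, so they give no direct guide to size or direction here. No change beyond the scatter is expected, though with wide uncertainty. The estimated step is a 1.1-fold lower number from compound 3 to compound 4 (0.04 log units; within the scatter). The expected value for compound 4 is 1600 nM, with an estimated range from 500 nM to 5500 nM.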

Compound 4, half-maximal inhibitory concentration: 1080 nM
The estimate for compound 4 lay 1.5-fold (0.17 log units) above the measured number, within the range that was stated.
By their numbers in this assay, from the lowest: compound 1; then compounds 4 and 3 (each within the scatter of the next); then compound 2.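

Going from phenyl to 4-methylphenyl in this assay gives a 1.6-fold lower number from compound 3 to compound 4 (0.21 log units; within the scatter), so this place on the molecule accepts one added methyl with no change that stands clear of the scatter. Among these compounds, the earlier steps showed only that changing the group on the nitrogen can move the number well beyond the scatter. No measurement at hand bears on why this step is small.

As far as these compounds go, a chlorine, an ethyl chain or a carboxylic acid at this place remains open. So does whether the same methyl would behave alike on compound 1, with its 3,5-dimethoxyphenyl group.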